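The compounds below may be only part of what the source reports. "The series", "measured", "known", "first", "only" and "open" are said of these compounds alone.

Compound 1 `C=C(C)c1cn(-c2cccc(C(=O)/C=C/c3ccc(OC)c(O)c3)c2)nn1` gives 7760 nM in a functional assay on RAW264.7 cells (Mus musculus) for inhibition, with a stated time of 4 days; a lower number here means a stronger inhibitor, a higher number a weaker inhibitor; compound 2 `COc1ccc(/C=C/C(=O)c2cccc(-n3cc(-c4ccc(C)cc4)nn3)c2)cc1O` gives 1700 nM.

For the measured compounds named here, compound 2 stands lowest of the two numbers, with compound 1 as its only neighbour a 4.6-fold lower number from compound 1 to compound 2 (0.66 log units; beyond the scatter). Compound 3 `COc1ccc(/C=C/C(=O)c2cccc(-n3cc(-c4cc(F)cc(F)c4)nn3)c2)cc1O` differs from compound 2 only at the five-membered aromatic ring with 3 nitrogen (3,5-difluorophenyl in place of 4-methylphenyl on an aromatic carbon). Going by the values given here, the single measured step swaps a chain for an aromatic ring and does not bear directly on one aromatic ring replacing another, so no step beyond the scatter is expected for compound 3 a 1.2-fold higher number from compound 2 to compound 3 (0.07 log units; within the scatter). Compound 3 is estimated at 2000 nM (range 700 nM to 6000 nM).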

Compound 3, half-maximal inhibitory concentration: 7140 nM
The estimate for compound 3 lay 3.6-fold (0.55 log units) below the measured number; measured number above the stated range.
By their numbers in this assay, from the lowest: compound 2; then compounds 3 and 1 (each within the scatter of the next).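

At this aromatic carbon, the mere presence of an aromatic ring does not settle the outcome: 3,5-difluorophenyl in place of 4-methylphenyl brings a 4.2-fold higher number from compound 2 to compound 3 (0.62 log units; beyond the scatter). Set against 1-methylethenyl, 3,5-difluorophenyl brings no gain, with a 1.1-fold lower number from compound 1 to compound 3 (0.04 log units; within the scatter). No measurement is at hand that accounts for this difference between the two aromatic rings.

The compounds shown leave open whether the methyl group or the two fluorines set this gap. They also leave open how a plain phenyl, a 4-fluorophenyl or a phenyl bearing an amine would stand at this carbon.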